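Carboxy in Place of Chloro: Expected Cell Toxicity of Compound 3

The compounds below may be only part of what the source reports. "The series", "measured", "known", "first", "only" and "open" are said of these compounds alone.

Measured so far:
Compound 1, `O=c1cc(-c2ccccc2)oc2cc(OCCCCNc3nc4ccc(Cl)cc4s3)cc(O)c12`: 338 ug/mL
Compound 2, `O=c1cc(-c2ccccc2)oc2cc(OCCCCNc3nc4ccc(C(F)(F)F)cc4s3)cc(O)c12`: 278 ug/mL

Both were tested in an ADME assay on MDCK cells (Canis lupus familiaris) for cytotoxicity, read by sulforhodamine B assay, with a stated time of 48 h; on this read-out lower numbers stand for stronger inhibition and higher numbers for weaker inhibition. Among the compounds with values here, compound 1 gives 338 ug/mL, the highest of the two numbers; the only measured step, a 1.2-fold lower number from compound 1 to compound 2 (0.08 log units; within the scatter), came with trifluoromethyl in place of chloro on an aromatic carbon. Compound 3, `O=C(O)c1ccc2nc(NCCCCOc3cc(O)c4c(=O)cc(-c5ccccc5)oc4c3)sc2c1`, differs from compound 1 by carboxy in place of chloro on an aromatic carbon. Within the data shown here, no measured step exchanges chloro for carboxy, so the one step available offers only a loose guide and suggests a small effect. The expected step is therefore a 1.0-fold lower number from compound 1 to compound 3 (0.01 log units; within the scatter), not beyond the scatter. Compound 3 is estimated at 330 ug/mL, between 150 ug/mL and 650 ug/mL.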

Compound 3, half-maximal inhibitory concentration: 324 ug/mL
Compound 3: middle estimate off by 1.0-fold (0.01 log units), on the high side; measured number inside the range.
By their numbers in this assay, from the lowest: compounds 2, 3 and 1 (each within the scatter of the next).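

In this assay carboxy, with three heavy atoms and a hydrogen-bond donor, takes the place of chloro on the aromatic carbon with no change beyond the scatter (a 1.0-fold lower number from compound 1 to compound 3 (0.02 log units; within the scatter)). Set against trifluoromethyl at the same place, carboxy also stays within the scatter (a 1.2-fold higher number from compound 2 to compound 3 (0.07 log units; within the scatter)), so these three groups give no reading difference here. Nothing available explains this lack of difference. On these data alone, whether an amine or an amide at this place would give a number beyond the scatter stays open. So does the effect of a longer chain on the shared core.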